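This account rests on a few compounds, and the source may have more. Where it says the series, first, only, none or still open, it means among the compounds named here.

Of the compounds shown here, three sharing one core have been measured in a functional assay on A549 cells (Homo sapiens) for inhibition, read by MTT assay, with a stated time of 72 h; a higher number here means a weaker inhibitor, a lower number a stronger inhibitor. Compound 1 `COc1cc2c(Oc3ccc(NC(=O)c4nn(-c5ccccc5C)cc(C)c4=O)cc3)ccnc2cc1OCC(=O)NO` gives 5980 nM, compound 2 `COc1cc2c(Oc3ccc(NC(=O)c4nn(-c5ccc(F)c(Cl)c5)cc(C)c4=O)cc3)ccnc2cc1OCCCCCCC(=O)NO` gives 380 nM, and compound 3 `COc1cc2c(Oc3ccc(NC(=O)c4nn(-c5cccc(C(F)(F)F)c5)cc(C)c4=O)cc3)ccnc2cc1OCCCCCCC(=O)NO` gives 780 nM. Compound 3 thus holds the middle place of the three, much nearer to compound 2 than to compound 1.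

Compound 4 `COc1cc2c(Oc3ccc(NC(=O)c4nn(-c5ccccc5C)cc(C)c4=O)cc3)ccnc2cc1OCCCCCCC(=O)NO` keeps the long chain of compound 3 and changes one group: 2-methylphenyl in place of 3-(trifluoromethyl)phenyl on an aromatic nitrogen. In words, 2-methylphenyl takes the place of 3-(trifluoromethyl)phenyl on an aromatic nitrogen. Among the compounds with values here, the closest precedent is a swap at that same nitrogen, a 2.1-fold higher number from compound 2 to compound 3 (0.31 log units; beyond the scatter), which is modest in size. The 2-methylphenyl group of compound 4 also stands on a shorter chain in compound 1, so the 5980 nM of compound 1 cannot show what the group alone does.

With one modest precedent, no step beyond the scatter is expected in this assay, and the estimated step is a 1.0-fold higher number from compound 3 to compound 4 (0.01 log units; within the scatter). For compound 4 the estimated value is 800 nM, with an expected range from 300 nM to 2000 nM.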

Compound 4, half-maximal inhibitory concentration: 3130 nM
Compound 4: middle estimate off by 3.9-fold (0.59 log units), on the low side; the whole stated range lies below it.
By their numbers in this assay, from the lowest: compound 2; then compound 3; then compounds 4 and 1 (each within the scatter of the next).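

In this assay, the group on the aromatic nitrogen proves able to move the number more than the first swap showed: a 2.1-fold higher number from compound 2 to compound 3 (0.31 log units; beyond the scatter), whereas 2-methylphenyl gives a 4.0-fold higher number from compound 3 to compound 4 (0.60 log units; beyond the scatter) and an 8.2-fold higher number from compound 2 to compound 4 (0.92 log units; beyond the scatter). With 2-methylphenyl held constant, 5-(hydroxycarbamoyl)pentyl in place of hydroxycarbamoyl gives a 1.9-fold lower number from compound 1 to compound 4 (0.28 log units; within the scatter), a step within the scatter, so for this group the two chains cannot be told apart. No measurement at hand accounts for the effect of the 2-methylphenyl group.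

The compounds shown leave open whether the chain would matter as little with 3-chloro-4-fluorophenyl or 3-(trifluoromethyl)phenyl on the nitrogen. They also leave open where a plain phenyl group would fall, which would help show whether the methyl group itself plays a part in the step.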